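The source may report more compounds than this note shows. Statements on the series, on what has been measured and on what is new or still open speak of the compounds shown alone.

Compound 3, with the structure `N=C(NCCCc1c[nH]cn1)NCCC(c1ccncc1)c1ccc(F)cc1`, is the point of departure. Across the three compounds measured in a functional assay on ileum for antagonist activity at histamine H1 receptor (Cavia porcellus) (a higher number here means weaker binding, a lower number tighter binding), compound 3 gives 37.2 nM, the lowest of the three numbers. Compound 1, with the structure `N=C(NCCCc1c[nH]cn1)NCCC(c1ccccc1)c1ccccn1`, gives 97.7 nM in this assay, and compound 2, with the structure `N=C(NCCCc1c[nH]cn1)NCCC(c1ccc(F)cc1)c1cccnc1`, gives 195 nM. Going by the values given here, the only single-place step among them, a 5.2-fold lower number from compound 2 to compound 3 (0.72 log units; beyond the scatter), shows that moving the ring nitrogen within the pyridine already shifts the number beyond the scatter.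

Compound 4 has the structure `N=C(NCCCc1c[nH]cn1)NCCC(c1ccccc1)c1ccc(F)cc1`. The change from compound 3 is phenyl in place of pyridin-4-yl on a saturated chain carbon bound to an aromatic carbon and a saturated chain carbon. Among the compounds with values here, no measured step removes a pyridine nitrogen altogether, so the step from compound 2 to compound 3 bears on it only indirectly; compound 1, which also carries a phenyl, and compound 3 differ in more than one place. For compound 4 the number in this assay is therefore expected to stay close to that of compound 3, with a wide range, a 1.6-fold higher number from compound 3 to compound 4 (0.21 log units; within the scatter). Compound 4 is estimated at 60 nM, between 15 nM and 250 nM.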

Compound 4, dissociation constant: 34.7 nM
The estimate for compound 4 lay 1.7-fold (0.24 log units) above the measured number; low and high end bracket the measured number.
By their numbers in this assay, from the lowest: compounds 4 and 3 (each within the scatter of the next); then compounds 1 and 2 (each within the scatter of the next).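

In this assay, phenyl in place of pyridin-4-yl on this saturated chain carbon gives a step within the scatter (a 1.1-fold lower number from compound 3 to compound 4 (0.03 log units; within the scatter)), so among these compounds the ring nitrogen of pyridin-4-yl is not required to keep the number of compound 3. Phenyl at the same place separates from pyridin-3-yl beyond the scatter (a 5.6-fold lower number from compound 2 to compound 4 (0.75 log units; beyond the scatter)), which marks compound 2 as the one set apart among the three compounds carrying 4-fluorophenyl, and 4-fluorophenyl in place of pyridin-2-yl is also a step beyond the scatter (a 2.8-fold lower number from compound 1 to compound 4 (0.45 log units; beyond the scatter)). Nothing on hand accounts for these steps.

Going by these compounds, whether a saturated ring such as cyclohexyl, or a thienyl ring, at this place would keep the number remains open. So does the part played by the fluorine of 4-fluorophenyl, set against chlorine at that ring.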